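The source may report more compounds than this note shows. Statements on the series, on what has been measured and on what is new or still open speak of the compounds shown alone.

Measured so far:
compound 1 `CCOC(=O)c1c(O)c2cccnc2n(-c2ccccc2)c1=O` — 15.5%
compound 2 `O=C(Nc1nccs1)c1c(O)c2cccnc2n(-c2ccccc2)c1=O` — 2.5%

Notes on the series. In a functional assay on the whole organism for inhibition, with Rattus norvegicus as the target, read by cytopathic effect and paw edema, at a dose of 100 mg/kg by the oral route (on this read-out lower numbers stand for less inhibition and higher numbers for more inhibition at the one dose given (going by the name of the read-out)), compound 1 gives 15.5%, while compound 2 gives 2.5%. For the measured compounds named here, the one step joining them, a number 13 percentage points lower from compound 1 to compound 2 (beyond the scatter), sets (1,3-thiazol-2-yl)amino in place of ethoxy on the carbonyl carbon of the shared core. Compound 2 therefore stands at the lowest of the two numbers seen in this assay, with compound 1 the nearest and higher, beyond the scatter.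

Compound 3 `O=C(NCc1ccncc1)c1c(O)c2cccnc2n(-c2ccccc2)c1=O` remains to be measured in this assay. It differs from compound 2 as follows: (pyridin-4-yl)methyl in place of 1,3-thiazol-2-yl on an amide-type nitrogen The group on the amide-type nitrogen changes from (1,3-thiazol-2-yl)amino to ((pyridin-4-yl)methyl)amino. Going by the values given here, no measured step alters the group on this amide-type nitrogen; the only step known, a number 13 percentage points lower from compound 1 to compound 2 (beyond the scatter), concerns the ethoxy to (1,3-thiazol-2-yl)amino exchange on the carbonyl carbon and gives no direct guide here. The step of a number 5.5 percentage points higher from compound 2 to compound 3 (within the scatter) is therefore expected to stay within the scatter, with no direction claimed. For compound 3 the estimate in this assay is 8%, within a range from -5% to 25%.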

Compound 3, a percentage reported as inhibition, in the whole organism at one dose (the size of the read-out at that dose, not a potency): 15.4%
Compound 3: middle estimate off by 7.4 percentage points, on the low side, within the range that was stated.
By their numbers in this assay, from the lowest: compound 2; then compounds 3 and 1 (each within the scatter of the next).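

In this assay the group on the amide-type nitrogen proves able to move the read-out: a number 12.9 percentage points higher from compound 2 to compound 3 (beyond the scatter) when (pyridin-4-yl)methyl stands in place of 1,3-thiazol-2-yl, whereas the earlier pair showed only an exchange of ethoxy on the carbonyl carbon. For the compounds shown here, the amide link alone therefore does not go with the low number, for a number 0.1 percentage points lower from compound 1 to compound 3 (within the scatter) and thus ((pyridin-4-yl)methyl)amino and ethoxy on the carbonyl carbon cannot be told apart in this read-out, leaving compound 2 as the one member set apart beyond the scatter from both others. No measurement at hand accounts for either step.

The compounds shown leave open whether the step from compound 2 to compound 3 goes with the change of ring or with the methyl link on the amide-type nitrogen, as the two change together. Also open, as far as these compounds go, is how a benzyl group, a directly attached pyridin-4-yl ring or a morpholine amide would read at this position, and all three numbers remain readings at a single dose, so they give no potency.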